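The source may hold more compounds than are shown below. What is called first, only, known or untested is meant among the compounds shown, and "the series" means these compounds.

Going by the values given here, in a functional assay on HeLa cells (Homo sapiens) for cytotoxicity, read by MTT assay, with a stated time of 24 h (on this read-out higher numbers stand for weaker inhibition and lower numbers for stronger inhibition), two compounds with a shared core have numbers so far. Compound 1 `COc1cc(/C=C(\C#N)C(=O)N/N=C(\C)c2c(O)c3ccc(O)cc3oc2=O)ccc1O` gives 10500 nM, and compound 2 `C/C(=N\NC(=O)/C(C#N)=C/c1ccc(Br)cc1)c1c(O)c2ccc(O)cc2oc1=O` gives 10600 nM. Compound 2 thus stands level with compound 1, the two values lying within the scatter of each other. Compound 3 `C/C(=N\NC(=O)/C(C#N)=C/c1ccccc1[N+](=O)[O-])c1c(O)c2ccc(O)cc2oc1=O` has not yet been measured in this assay. It differs from compound 2 on a double-bonded chain carbon bound to a double-bonded chain carbon, where 2-nitrophenyl takes the place of 4-bromophenyl: 2-nitrophenyl in place of 4-bromophenyl on a double-bonded chain carbon bound to a double-bonded chain carbon. Among the compounds with values here, only one measured step bears on this place. That step, a 1.0-fold higher number from compound 1 to compound 2 (0.00 log units; within the scatter), put 4-bromophenyl in place of 4-hydroxy-3-methoxyphenyl and stayed within the scatter, so it points in neither direction. Within the data shown here, it is thin evidence, as no measured compound carries 2-nitrophenyl. No change beyond the scatter is therefore expected, and the estimated step is a 1.1-fold lower number from compound 2 to compound 3 (0.03 log units; within the scatter). For compound 3 the estimated value is 10000 nM, with an expected range from 4000 nM to 25000 nM.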

Compound 3, half-maximal inhibitory concentration: 10300 nM
Compound 3: middle estimate off by 1.0-fold (0.01 log units), on the low side; the range from low to high includes it.
By their numbers in this assay, from the lowest: compounds 3, 1 and 2 (each within the scatter of the next).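

In this assay, the place on a double-bonded chain carbon bound to a double-bonded chain carbon has now taken a third substituted phenyl group without any change beyond the scatter: 2-nitrophenyl replacing 4-bromophenyl gives (a 1.0-fold lower number from compound 2 to compound 3 (0.01 log units; within the scatter)), and 2-nitrophenyl replacing 4-hydroxy-3-methoxyphenyl gives (a 1.0-fold lower number from compound 1 to compound 3 (0.01 log units; within the scatter)). Compared with the single earlier step, this extends the flat result to a group that brings nitrogen and oxygen atoms and hydrogen-bond acceptors absent from 4-bromophenyl, and whose name places its substituent at 2 rather than 4. Among these three compounds, then, the read-out does not separate the groups at this place, and no supporting measurement accounts for that.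

The compounds shown leave open whether this holds beyond substituted phenyl groups, for instance with a phenyl ring carrying an amine or a carboxylic acid, or with a longer chain in place of the ring. They also leave open whether changes elsewhere on the shared core, such as to the nitrile or the methyl group on the chain, would move the number in a way this place has not.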